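The source may report more compounds than this note shows. Statements on the series, on what has been measured and on what is new or still open speak of the compounds shown alone.

Compound 1 `CC1(C)CNC(=O)c2sc(Nc3ccc(I)cc3F)c(C(=O)NC[C@H]3CCCN3)c2C1` is the better of the two measured compounds in a functional assay on HT-29 cells (Homo sapiens) for antiproliferative activity; on this read-out higher numbers stand for weaker inhibition and lower numbers for stronger inhibition: compound 1 gives 120 nM, the lowest number of the pair. Compound 2 `CC1(C)CNC(=O)c2sc(Nc3ccc(I)cc3F)nc2C1` gives 8870 nM in this assay, a far higher number, and the gap between the two lies well beyond the scatter of the method.

Compound 3 `CC(C)(N)CNC(=O)c1c(Nc2ccc(I)cc2F)sc2c1CC(C)(C)CNC2=O` has not been measured. It differs from compound 1 in one place: 1-amino-1-methylethyl in place of pyrrolidin-2-yl on a saturated chain carbon bound to an amide-type nitrogen. The shared core, including the iodo-fluoro-substituted anilino group and the carboxamide on the thiophene, is unchanged; only the group on the saturated chain carbon bound to the amide-type nitrogen is exchanged.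

Within the data shown here, no measured pair shows this kind of exchange, so there is no direct precedent to draw on. Since compound 1 carries the side chain that compound 2 lacks and gives the much lower number, the side chain matters, and compound 3 keeps a closely related one. Compound 3 is therefore expected to stay near compound 1, with a step of a 1.8-fold higher number from compound 1 to compound 3 (0.26 log units; within the scatter) that is small, most likely a modest loss. Compound 3 is estimated at 220 nM, expected to fall between 60 nM and 800 nM.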

Compound 3, half-maximal inhibitory concentration: 79 nM
Beside the measured number, compound 3's estimate is 2.8-fold (0.44 log units) above it; measured number inside the range.
By their numbers in this assay, from the lowest: compounds 3 and 1 (each within the scatter of the next); then compound 2.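

In this assay, 1-amino-1-methylethyl in place of pyrrolidin-2-yl on a saturated chain carbon bound to an amide-type nitrogen gives a 1.5-fold lower number from compound 1 to compound 3 (0.18 log units; within the scatter), so the two compounds cannot be told apart on this read-out. At this position, the five-membered non-aromatic ring and the defined stereocentre of the group in compound 1 are therefore not required for a number of this size: compound 3, with no ring and no stereocentre in this group, reads alike. Nothing available explains this likeness.

The compounds shown leave open whether the amine nitrogen of this group is needed, which a hydroxyl or a plain isobutyl group in its place would test. They also leave open how a longer chain carrying the amine would read in this assay at this position.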